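Demethylation of an aryl methoxy group and cytotoxicity

A few compounds are considered here, and "the series" means these few. Any claim that something is new, unique, unknown or untested is made for them only; others in the source may bear on it.

Compound 1 `COc1cc([C@H]2CC(C)(O)[C@@H]3CC[C@@H](C)C[C@H]3O2)cc(OC)c1OC` and compound 2 `COc1cc([C@H]2CC(C)(O)[C@@H]3CC[C@@H](C)C[C@H]3O2)cc(OC)c1O` share one core, while compound 3 `COc1ccc([C@H]2CC(C)(F)[C@@H]3CC[C@@H](C)C[C@H]3O2)cc1OC` and compound 4 `COc1ccc([C@H]2CC(C)(F)[C@@H]3CC[C@@H](C)C[C@H]3O2)cc1O` share another; the difference between the two cores is not broken down here. In an ADME assay on MDCK cells (Canis lupus familiaris) for cytotoxicity, read by MTT assay, with a stated time of 48 h (on this read-out lower numbers stand for higher toxicity in this test and higher numbers for lower toxicity in this test), compound 1 gives 405000 nM and compound 2 gives 473000 nM, so the change hydrogen in place of methyl on an oxygen on an aromatic ring produced a 1.2-fold higher number from compound 1 to compound 2 (0.07 log units; within the scatter). Compound 3 gives 20000 nM in this assay, the lowest of the three measured numbers. The same change, (hydrogen in place of methyl on an oxygen on an aromatic ring), leads from compound 3 to compound 4. The step from compound 3 to compound 4 is expected to be a 1.2-fold higher number from compound 3 to compound 4 (0.06 log units; within the scatter), about as small as the earlier one, because the matching change from compound 1 to compound 2 gave a 1.2-fold higher number from compound 1 to compound 2 (0.07 log units; within the scatter). Compound 4 is therefore estimated at 23000 nM in this assay, between 10000 nM and 50000 nM.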

Compound 4, half-maximal cytotoxic concentration: 136000 nM
Estimate against measurement, compound 4: 5.9-fold (0.77 log units) below; the measured number lies above the stated range.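

In this assay, the change from methoxy to hydroxy gave a 6.8-fold higher number from compound 3 to compound 4 (0.83 log units; beyond the scatter), and it did not carry over in size from one core to the other: the same change on two cores in this assay, a 1.2-fold higher number (0.07 log units; within the scatter) from compound 1 to compound 2 and a 6.8-fold higher number (0.83 log units; beyond the scatter) from compound 3 to compound 4, 5.8-fold (0.77 log units) apart, beyond the scatter of two such steps. In these two pairs, then, the size of the step depended on the core, and a step read on one core was a poor guide to the step on the other. This does not show which feature of the cores sets the size of the step, and two pairs give no rule for the series.

From the compounds shown here alone, it remains open whether the larger step would persist on a core changed in only one place from that of compound 3. Going by these compounds, it also remains open how an amine or an ethoxy group in place of the hydroxy would behave on either core.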